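The source may report more compounds than this note shows. Statements on the series, on what has been measured and on what is new or still open speak of the compounds shown alone.

Measured compounds:
- compound 1 `CSc1ccc(C)cc1NCC1=NCCN1`: 8.91 nM
- compound 2 `Cc1ccc(S(C)(=O)=O)c(NCC2=NCCN2)c1`: 1120 nM

In a functional assay on CHO cells for agonist activity at Alpha-2C adrenergic receptor (Homo sapiens) (on this read-out higher numbers stand for an effect only at larger amounts of compound and lower numbers for an effect already at smaller amounts), compound 1 gives 8.91 nM and compound 2 gives 1120 nM. Compound 1 thus stands at the lowest of the two numbers; the nearest measured value is that of compound 2, reached by a 130-fold higher number from compound 1 to compound 2 (2.10 log units; beyond the scatter), a step that replaces methylsulfonyl with methylsulfanyl on an aromatic carbon.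

Compound 3 `CSc1ccc(F)cc1NCC1=NCCN1` is not yet measured. Compared with compound 1 it shows (fluoro in place of methyl on an aromatic carbon). For the measured compounds named here, the methylsulfanyl group that distinguishes compound 1 from compound 2 is kept unchanged in compound 3, so the one measured step does not bear on this change, and no measured step in this assay speaks to a methyl-to-fluoro exchange. With nothing in the data pointing either way, compound 3 is expected to stay close to compound 1, with a 1.1-fold higher number from compound 1 to compound 3 (0.05 log units; within the scatter) not beyond the scatter. Compound 3 is therefore estimated at 10 nM, within 3 nM to 40 nM.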

Compound 3, half-maximal effective concentration: 5.62 nM
The estimate for compound 3 lay 1.8-fold (0.25 log units) above the measured number, and the stated range covers the measured number.
By their numbers in this assay, from the lowest: compounds 3 and 1 (each within the scatter of the next); then compound 2.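

In this assay, putting fluoro on the aromatic carbon para to a methylsulfanyl group in place of methyl gives a 1.6-fold lower number from compound 1 to compound 3 (0.20 log units; within the scatter), so this exchange leaves the number within the scatter. The change at this position therefore stands apart from the large shift seen at the sulfur group, a 130-fold higher number from compound 1 to compound 2 (2.10 log units; beyond the scatter), and it shows that methyl is not needed here to keep the number at the level of compound 1. Nothing at hand gives a reason for this result.

Only methyl and fluoro are shown at this position, which leaves open how a chloro group, a methoxy group, an amine or a carboxylic acid would fare there. On these data alone, it is also open whether fluoro would leave the number equally unchanged alongside the methylsulfonyl group of compound 2.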